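The source may hold more compounds than are shown below. What is called first, only, known or untested is meant among the compounds shown, and "the series" means these compounds.

In a functional assay on HeLa cells (Homo sapiens) for cytotoxicity, read by WST assay, with a stated time of 48 h (on this read-out higher numbers stand for weaker inhibition and lower numbers for stronger inhibition), three compounds of this series have been measured. Compound 1 `CCCCCC/C=C/C[C@H]1C[C@@H]([C@@H](O)c2ccccc2)CO[C@@H]1c1ccccc1` gives 7400 nM. Compound 2 `COc1ccc([C@H](O)[C@H]2CO[C@H](c3ccc(OC)c(OC)c3)[C@@H](C/C=C/c3ccc(OC)c(OC)c3)C2)cc1` gives 46000 nM. Compound 3 `COc1ccc([C@H]2OC[C@H]([C@@H](O)c3ccc(OC)c(OC)c3)C[C@@H]2C/C=C/c2ccccc2)cc1OC` gives 14800 nM. Among these three numbers, the one for compound 1 is the lowest, but the gap to compound 3 lies within the usual scatter of repeated measurements, so the two cannot be set in order; only the gap to compound 2 lies beyond the scatter. For the measured compounds named here, compounds 2 and 3 differ from compound 1 in several places at once, so no single-point step between measured compounds is available.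

Compound 4 `O[C@@H](c1ccccc1)[C@H]1CO[C@H](c2ccccc2)[C@@H](C/C=C/c2ccccc2F)C1` has not yet been measured. It differs from compound 1 in one place: 2-fluorophenyl in place of hexyl on a double-bonded chain carbon bound to a double-bonded chain carbon. Going by the values given here, no measured pair isolates this change, so the expectation for compound 4 rests on compound 1, which in this assay gives 7400 nM. The account expects a modest rise in number in this assay, of a size that may not clear the scatter, so that the step of a 1.6-fold higher number from compound 1 to compound 4 (0.21 log units; within the scatter) is estimated as small. On this basis compound 4 is expected to give 12000 nM, with a range from 4000 nM to 36000 nM, in this assay.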

Compound 4, half-maximal inhibitory concentration: 9730 nM
For compound 4 the middle estimate is 1.2-fold (0.09 log units) above the measured one; the range from low to high includes it.
By their numbers in this assay, from the lowest: compounds 1, 4 and 3 (each within the scatter of the next); then compound 2.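

In this assay the series now has its first single-point step: 2-fluorophenyl in place of hexyl on a double-bonded chain carbon bound to a double-bonded chain carbon gives a 1.3-fold higher number from compound 1 to compound 4 (0.12 log units; within the scatter) and so leaves the two compounds without an order. At this place, then, a chain with no ring and a group with one six-membered aromatic ring give numbers that cannot be told apart in this assay, even though the exchange replaces the whole hexyl group. Nothing available on the properties of these groups or compounds bears on this result, so it stands as an observation without an explanation.

The compounds shown leave open what the fluorine contributes apart from the aromatic ring, and whether a longer chain, an amine or a carboxylic acid at this place would also stay within the scatter of compound 1. They also leave open whether the same exchange would read alike on a core carrying methoxy groups.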